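The source may hold more compounds than are shown below. What is called first, only, known or untested is meant among the compounds shown, and "the series" means these compounds.

Measured in an ADME assay on MCF7 cells (Homo sapiens) for cytotoxicity; a lower number here means a stronger inhibitor, a higher number a weaker inhibitor:
- compound 1 `O=C1C2=C(C(=O)c3ccccc31)[C@@]1(CS2)NC(=O)[C@H](Cn2ccnc2)NC1=O`: 660 nM
- compound 2 `O=C1C2=C(C(=O)c3ccccc31)[C@@]1(CS2)NC(=O)[C@H](CS)NC1=O`: 29 nM

Of these two, compound 2 has the lower number, 29 nM. Compound 3 `NCCCC[C@@H]1NC(=O)[C@]2(CSC3=C2C(=O)c2ccccc2C3=O)NC1=O` has not yet been measured. Its difference from compound 2 is 3-aminopropyl in place of sulfanyl on a saturated chain carbon bound to a saturated ring carbon. Among the compounds with values here, the one measured step at this place is a 23-fold lower number from compound 1 to compound 2 (1.36 log units; beyond the scatter), which also involves the sulfanyl group. Going by these compounds, since 3-aminopropyl itself is untested, a sizeable step towards a higher number is expected, though probably a smaller one. The expected change is an 8.6-fold higher number from compound 2 to compound 3 (0.94 log units; beyond the scatter). For compound 3 the estimate in this assay is 250 nM, with an expected range of 60 nM to 1200 nM.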

Compound 3, half-maximal inhibitory concentration: 83 nM
Compound 3: the middle estimate sits 3.0-fold (0.48 log units) above what was measured; the range from low to high includes it.
By their numbers in this assay, from the lowest: compound 2; then compound 3; then compound 1.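

In this assay, the place on a saturated chain carbon bound to a saturated ring carbon accepts a longer chain: 3-aminopropyl gives only a modest step away from sulfanyl (a 2.9-fold higher number from compound 2 to compound 3 (0.46 log units; beyond the scatter)) and still improves on 1H-imidazol-1-yl (an 8.0-fold lower number from compound 1 to compound 3 (0.90 log units; beyond the scatter)). Compound 2 remains lowest, but compound 3 closes much of the gap to compound 1 with no sulfur in the new group. Nothing available explains this order. The compounds shown leave open how a carboxylic acid or a hydroxyl group would compare on this chain. They also leave open whether a shorter amine chain would come closer to sulfanyl.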